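The source may hold more compounds than are shown below. What is called first, only, known or untested is meant among the compounds shown, and "the series" means these compounds.

Among the measured compounds shown here, compound 2 `CCCCOC(=O)NS(=O)(=O)c1sc(CC(C)C)cc1-c1ccc(Cc2nnc(C(F)(F)F)o2)cc1` gives 328 nM in an assay on membranes from uterus for displacement of a labelled ligand from Angiotensin type II receptor (Sus scrofa), with a stated time of 1.5 h (a higher number here means a weaker inhibitor, a lower number a stronger inhibitor), the highest of the two numbers measured so far; its nearest neighbour, compound 1 `CCCCOC(=O)NS(=O)(=O)c1sc(CC(C)C)cc1-c1ccc(Cc2nccs2)cc1`, gives 3.2 nM. For the measured compounds named here, the single measured step between them, a 100-fold higher number from compound 1 to compound 2 (2.01 log units; beyond the scatter), shows how strongly the group on the saturated chain carbon bound to an aromatic carbon can shift this assay. Compound 3 `CCCCOC(=O)NS(=O)(=O)c1sc(CC(C)C)cc1-c1ccc(CN2CCCC2=O)cc1` changes that same group again: 2-oxopyrrolidin-1-yl in place of 5-(trifluoromethyl)-1,3,4-oxadiazol-2-yl on a saturated chain carbon bound to an aromatic carbon. Going by the values given here, no measured step covers this new group, so the size of its effect is uncertain, though a return toward lower numbers is expected. Compound 3 is therefore estimated at 50 nM, between 8 nM and 400 nM, a step of a 6.6-fold lower number from compound 2 to compound 3 (0.82 log units; beyond the scatter).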

Compound 3, inhibition constant: 3.5 nM
Estimate against measurement, compound 3: 14-fold (1.15 log units) above, outside the stated range (below it).
By their numbers in this assay, from the lowest: compounds 1 and 3 (each within the scatter of the next); then compound 2.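

The 2-oxopyrrolidin-1-yl group recovers what 5-(trifluoromethyl)-1,3,4-oxadiazol-2-yl lost, with a 94-fold lower number from compound 2 to compound 3 (1.97 log units; beyond the scatter). Set against the 1,3-thiazol-2-yl group, it gives a 1.1-fold higher number from compound 1 to compound 3 (0.04 log units; within the scatter), so on this saturated chain carbon bound to an aromatic carbon, a non-aromatic ring serves as well as an aromatic one. Nothing measured here explains why the oxadiazole group stands apart. The compounds shown leave open whether a ring is needed at all, which an open-chain amine or a carboxylic acid in this place would test.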